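The compounds below may be only part of what the source reports. "The series", "measured", "known", "first", "only" and "open" are said of these compounds alone.

Three compounds share one core and differ only in the group attached to an amine nitrogen in a ring. Compound 1 `CC(C)N1CCN(Cc2csc(N)c2C(=O)c2ccc(Cl)cc2)CC1` carries isopropyl there, compound 2 `Nc1scc(CN2CCN(c3cc(Cl)cc(Cl)c3)CC2)c1C(=O)c1ccc(Cl)cc1` carries 3,5-dichlorophenyl, and compound 3 `Nc1scc(CN2CCN(c3ccc(F)cc3Cl)CC2)c1C(=O)c1ccc(Cl)cc1` carries 2-chloro-4-fluorophenyl. In an assay on CHO cells for displacement of a labelled ligand from adenosine receptor A1 (Homo sapiens), read by scintillation counting, with a stated time of 120 min, tested at 10 uM (on this read-out lower numbers stand for less inhibition and higher numbers for more inhibition at the one concentration tested (going by the name of the read-out)), compound 1 gives 0%, compound 2 gives 1% and compound 3 gives 0%. The steps between them are small: a number 1 percentage points higher from compound 1 to compound 2 (within the scatter), no change at the digits printed from compound 1 to compound 3 (within the scatter) and a number 1 percentage points lower from compound 2 to compound 3 (within the scatter). Compound 3 thus stands level with compound 1, the two together at the bottom of the three numbers, with compound 1 as its nearest neighbour and compound 2 as its furthest, and none of these differences goes beyond the scatter.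

Compound 4 `COc1ccc(N2CCN(Cc3csc(N)c3C(=O)c3ccc(Cl)cc3)CC2)cc1` is the next member of this series. 4-methoxyphenyl in place of 2-chloro-4-fluorophenyl on an amine nitrogen in a ring The two measured steps that swap one group for another on that ring nitrogen, from compound 1 to compound 3 and from compound 2 to compound 3, both stayed within the scatter, as did the step from compound 1 to compound 2, so exchanging the group there has not moved the read-out so far. For compound 4 in this assay no step beyond the scatter is therefore expected, a number 1 percentage points higher from compound 3 to compound 4 (within the scatter). Compound 4 is expected to give 1%, within a range from -6% to 10%.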

Compound 4, a percentage reported as inhibition, at one concentration (the size of the read-out at that concentration, not a potency): 0%
Estimate against measurement, compound 4: 1 percentage points above; the range from low to high includes it.
By their numbers in this assay, from the lowest: compounds 1, 3, 4 and 2 (each within the scatter of the next).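

In this assay, putting 4-methoxyphenyl in place of 2-chloro-4-fluorophenyl on the amine nitrogen in a ring gives no change at the digits printed from compound 3 to compound 4 (within the scatter), so this position now has a halogen-free aromatic group with the same count of 8 heavy atoms and with 1 hydrogen-bond acceptor where the group it replaces has 0, and the read-out stays within the scatter. Set against the other two groups, the same 4-methoxyphenyl gives a number 1 percentage points lower from compound 2 to compound 4 (within the scatter) and no change at the digits printed from compound 1 to compound 4 (within the scatter), so isopropyl and all three substituted phenyl groups now sit within the scatter of one another, and none of the four compounds goes against this flat picture. Nothing available bears on why the read-out stays so flat at this position.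

On these data alone, all four numbers lie so close to the bottom of the scale that they cannot rank these groups, so it remains open whether any group on this nitrogen can produce clear inhibition at the one concentration tested. A carboxylic acid on the phenyl ring, a pyridine ring or a benzyl group on this nitrogen could test that, as could changes elsewhere on the shared core, such as replacing the 4-chlorophenyl group on the carbonyl.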